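Chalcone analogues on A-375 cells: predicting a sulfone replacement

A few compounds are considered here, and "the series" means these few. Any claim that something is new, unique, unknown or untested is made for them only; others in the source may bear on it.

Measured compounds:
compound 1, `COc1ccc(/C=C/C(=O)c2ccc(OC)c3c2OC(C)(C)C=C3)cc1O`: 800 nM
compound 2, `CCC(=O)Oc1cc(/C=C/C(=O)c2ccc(OC)c3c2OC(C)(C)C=C3)ccc1OC`: 240 nM

Of these two numbers in a functional assay on A-375 cells (Homo sapiens) for cytotoxicity, read by MTT assay (on this read-out lower numbers stand for stronger inhibition and higher numbers for weaker inhibition), compound 1 has the higher one, and its nearest neighbour is compound 2, reached by a 3.3-fold lower number from compound 1 to compound 2 (0.52 log units; beyond the scatter), a modest step beyond the scatter when propanoyl takes the place of hydrogen on an oxygen on an aromatic ring.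

Compound 3, `COc1ccc(/C=C/C(=O)c2ccc(OC)c3c2OC(C)(C)C=C3)cc1CS(C)(=O)=O`, differs from compound 1 by (methylsulfonyl)methyl in place of hydroxy on an aromatic carbon. For the measured compounds named here, only one measured step bears on this: the step from compound 1 to compound 2, which also removes the hydroxy donor hydrogen and lowered the number modestly. The entering group here is a different one, so that step is only a rough guide. A modest lowering is expected, a 1.6-fold lower number from compound 1 to compound 3 (0.20 log units; within the scatter), with wide uncertainty. The estimate for compound 3 in this assay is 500 nM, within a range of 150 nM to 1600 nM.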

Compound 3, half-maximal inhibitory concentration: > 10000 nM
Compound 3 ended at the assay's limit (the forecaster's own chance of this, stated with the estimate: 5%); middle value at least 20-fold (1.30 log units) away from the limit.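

The value of compound 3 in this assay is a limit of the assay and not a number: the limit of > 10000 nM in this assay, at which 1 of the 3 values shown sits. Even so, the two steps can be read, and both are large and beyond the scatter: an at least 12-fold higher number from compound 1 to compound 3 (1.09 log units; beyond the scatter), and an at least 41-fold higher number from compound 2 to compound 3 (1.61 log units; beyond the scatter). The position on the aromatic ring ortho to a methoxy group therefore does not accept every replacement of the hydroxy, and the loss of the donor hydrogen alone does not account for the result, since compound 2 also lacks it and gives the lowest number of the three.

The compounds shown give no reason why (methylsulfonyl)methyl fails here, and they do not tell how far beyond the limit compound 3 lies. As far as these compounds go, whether an amine, a carboxylic acid or a longer ester chain at this position would keep the activity also remains open.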